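The source may hold more compounds than are shown below. What is called first, only, known or untested is meant among the compounds shown, and "the series" means these compounds.

Measured in a functional assay on MDA-MB-231 cells (Homo sapiens) for antiproliferative activity, read by MTT assay, with stated times of 72 h and 4 h; on this read-out higher numbers stand for weaker inhibition and lower numbers for stronger inhibition:
Compound 1 `CS(=O)(=O)c1ccc(C(=O)Nc2ccc(Cl)c(-c3nnc4c(Cl)cccn34)c2)c(Cl)c1` gives 37200 nM.
Compound 2 `O=C(Nc1ccc(Cl)c(-c2nnc3c(Cl)cccn23)c1)c1ccon1` gives only a limit of the assay, > 100000 nM.
Compound 3 `O=C(Nc1ccc(Cl)c(-c2nnc3c(Cl)cccn23)c1)c1ccccn1` gives 92000 nM.

Compound 1 stands lowest of the two numbers shown, with compound 3 nearest; compound 2 sits at the limit (the limit of > 100000 nM in this assay, at which 1 of the 3 values shown sits). Compound 4 `CS(=O)(=O)c1ccc(C(=O)Nc2ccc(Cl)c(-c3nnc4c(Cl)cccn34)c2)cc1` is derived from compound 1 by hydrogen in place of chloro on an aromatic carbon. Within the data shown here, the only measured step, an at least 1.0-fold lower number from compound 2 to compound 3 (0.03 log units; that floor lies within the scatter), concerns the group on the carbonyl carbon, not the chloro, so no measured step bears on this change. Compound 4 is therefore expected to stay within the scatter of compound 1, an expected step of a 1.1-fold higher number from compound 1 to compound 4 (0.03 log units; within the scatter). Compound 4 is estimated at 40000 nM, between 12000 nM and 110000 nM.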

Compound 4, half-maximal inhibitory concentration: > 100000 nM
Compound 4 gave a limit, no number; the forecaster's own chance of this, stated with the estimate: 15%; at least 2.5-fold (0.39 log units) between middle value and limit.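

Hydrogen in place of chloro, ortho to a large group and meta to a methylsulfonyl group, gives an at least 2.6-fold higher number from compound 1 to compound 4 (0.42 log units; beyond the scatter), the first measured sign in this assay that this chloro counts. Without it, the 4-(methylsulfonyl)phenyl group no longer stands clear of pyridin-2-yl, with an at least 1.0-fold higher number from compound 3 to compound 4 (0.03 log units; that floor lies within the scatter), and the step between the two limits cannot be read. Compound 4 ends at a limit, not a number: the limit of > 100000 nM in this assay, at which 2 of the 4 values shown sit.

As far as these compounds go, how far the loss goes therefore stays open. So does whether a fluoro, methyl or methoxy group on this carbon would hold the value of compound 1.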